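Sulfonyl in place of dienoyl on the amine nitrogen

The compounds below may be only part of what the source reports. "The series", "measured", "known", "first", "only" and "open" are said of these compounds alone.

In a functional assay on SiHa cells (Homo sapiens) for cytotoxicity, read by MTT assay, with a stated time of 48 h (on this read-out lower numbers stand for stronger inhibition and higher numbers for weaker inhibition), compound 1 `CCCCCCCCCCCCCCCCCCNC(=O)[C@@H](NC(=O)c1ccco1)[C@@H](C)O` gives 13400 nM and compound 2 `CCCCCCCCCCCCCCCCCCNC(=O)[C@@H](NC(=O)c1cccs1)[C@@H](C)O` gives 117000 nM. Compound 3 `C/C=C/C=C/C(=O)N[C@H](C(=O)NCCCCCCCCCCCCCCCCCC)[C@@H](C)O` reaches only the limit of this assay, > 200000 nM, so it stands as a limit and not as a number (the limit of > 200000 nM in this assay, at which 1 of the 3 values shown sits). The measured steps are an 8.7-fold higher number from compound 1 to compound 2 (0.94 log units; beyond the scatter), an at least 14-fold higher number from compound 1 to compound 3 (1.17 log units; beyond the scatter) and an at least 1.7-fold higher number from compound 2 to compound 3 (0.23 log units; that floor lies within the scatter). Compound 4 `CCCCCCCCCCCCCCCCCCNC(=O)[C@@H](NS(=O)(=O)c1ccc(C)cc1)[C@@H](C)O` differs from compound 3 by (4-methylphenyl)sulfonyl in place of (penta-1,3-dien-1-yl)carbonyl on an amine nitrogen. Within the data shown here, no measured step exchanges a carbonyl for a sulfonyl, so the three steps bear on it only loosely: the aromatic acyl groups of compound 1 and compound 2 gave numbers where the dienoyl of compound 3 did not. The expected step is an at least 3.3-fold lower number from compound 3 to compound 4 (0.52 log units; beyond the scatter). Compound 4 is estimated at 60000 nM, between 10000 nM and 250000 nM.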

Compound 4, half-maximal inhibitory concentration: 29800 nM
Compound 4: middle estimate off by 2.0-fold (0.30 log units), on the high side; low and high end bracket the measured number.
By their numbers in this assay, from the lowest: compound 1; then compound 4; then compound 2. At a limit, above all of these: compound 3.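

In this assay, the only sulfonyl shown on this amine nitrogen gives a number that sits among the aromatic acyl compounds, with a 3.9-fold lower number from compound 2 to compound 4 (0.59 log units; beyond the scatter) and a 2.2-fold higher number from compound 1 to compound 4 (0.35 log units; beyond the scatter). Against the dienoyl, an at least 6.7-fold lower number from compound 3 to compound 4 (0.82 log units; beyond the scatter), so an aromatic group on sulfonyl also gives a number where the dienoyl did not. That step is only a floor, as compound 3 stands at a limit: the limit of > 200000 nM in this assay, at which 1 of the 4 values shown sits.

Whether the lower number follows the sulfonyl link or the 4-methylphenyl ring stays open, as no pair shown changes one and keeps the other. A benzoyl or a methanesulfonyl group on the same nitrogen would separate the two.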